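Thienyl amidines: phenyl for cyclopropyl at the chain carbon

A few compounds are considered here, and "the series" means these few. Any claim that something is new, unique, unknown or untested is made for them only; others in the source may bear on it.

Working notes on a small set tested in a functional assay on the whole organism (plasma, strain Sprague-Dawley) with Rattus norvegicus as the target, with a stated time of 2 h, at a dose of 100 mg/kg by the oral route; a lower number here means a weaker effect, a higher number a stronger effect of the compound at the dose given. Compound 1 `c1ccc2c(C(/N=C3\CCCCCN3)C3CC3)cccc2c1` gives 21% in this assay. Compound 2 `c1csc(C(/N=C2\CCCCN2)C2CC2)c1` gives 28% in this assay, the higher of the two numbers, though its gap to compound 1 lies within the scatter, so the two are not told apart. Going by the values given here, compounds 1 and 2 differ in more than one place, and no single step connects them.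

Compound 3 `c1ccc(C(/N=C2\CCCCN2)c2cccs2)cc1` is not yet measured in this assay. Its difference from compound 2 is phenyl in place of cyclopropyl on a saturated chain carbon bound to an aromatic carbon and a double-bonded nitrogen. Among the compounds with values here, no measured pair shows the effect of this change, so the expected step from compound 2 to compound 3 in this assay is a number 2 percentage points higher from compound 2 to compound 3 (within the scatter), that is, no shift beyond the scatter in either direction. Compound 3 is therefore estimated at 30% in this assay, within a range from 10% to 55%.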

Compound 3, a percentage reported as inhibition, in the whole organism at one dose (the size of the read-out at that dose, not a potency): 32%
Compound 3: middle estimate off by 2 percentage points, on the low side; the range from low to high includes it.
By their numbers in this assay, from the lowest: compounds 1, 2 and 3 (each within the scatter of the next, the first and the last beyond it).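

Going by these compounds alone, the one single-place comparison in the set shows that, on the saturated chain carbon bound to an aromatic carbon and a double-bonded nitrogen, phenyl in place of cyclopropyl gives a number 4 percentage points higher from compound 2 to compound 3 (within the scatter) in this assay. A six-membered aromatic ring of carbon only can therefore stand at this position in place of a three-membered non-aromatic ring without a shift beyond the scatter, so compound 2 and compound 3 are not told apart at this single dose. Nothing measured here bears on the reason for this result.

Going by these compounds, whether an amine or a longer chain on the same carbon would move the read-out beyond the scatter remains open. Also open, on these data alone, is whether the same change would give a similar step on the core of compound 1, and, as the read-out is not a potency, how the compounds compare at other doses.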